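Chloro in place of methoxy on compound 2

The source may report more compounds than this note shows. Statements on the series, on what has been measured and on what is new or still open speak of the compounds shown alone.

Compound 1 `O=C(Nc1ccccc1)c1cc2cnc(Nc3ccc(N4CCNCC4)cn3)nc2n1C1CCCC1` and compound 2 `COc1ccccc1NC(=O)c1cc2cnc(Nc3ccc(N4CCNCC4)cn3)nc2n1C1CCCC1` share one core and differ in a single group. In a functional assay on BXPC-3 cells (Homo sapiens) for inhibition, read by MTT assay (a higher number here means a weaker inhibitor, a lower number a stronger inhibitor), compound 1 gives 5120 nM as its reading, and compound 2 gives 4120 nM as its reading. Methoxy in place of hydrogen on an aromatic carbon goes with a 1.2-fold lower number from compound 1 to compound 2 (0.09 log units; within the scatter) between them. Compound 2 therefore stands level with compound 1, and the two numbers cannot be told apart.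

Compound 3 `O=C(Nc1ccccc1Cl)c1cc2cnc(Nc3ccc(N4CCNCC4)cn3)nc2n1C1CCCC1` keeps everything in compound 2 except one group. The change is chloro in place of methoxy on an aromatic carbon at a spot described as ortho to a large group. Put simply, 2-methoxyphenyl becomes 2-chlorophenyl.

For the measured compounds named here, the only measured step at this place is a 1.2-fold lower number from compound 1 to compound 2 (0.09 log units; within the scatter) and it involves methoxy, so no measurement speaks for chloro directly. With that single small step as the guide, no change beyond the scatter is expected in this assay in either direction. The expected step is a 1.0-fold lower number from compound 2 to compound 3 (0.01 log units; within the scatter) and no larger shift is foreseen. Compound 3 is estimated at 4000 nM with an expected range from 1800 nM to 9000 nM for its reading.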

Compound 3, half-maximal inhibitory concentration: 4350 nM
The estimate for compound 3 lay 1.1-fold (0.04 log units) below the measured number; the measured number falls inside the stated range.
By their numbers in this assay, from the lowest: compounds 2, 3 and 1 (each within the scatter of the next).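

Chloro in place of methoxy on an aromatic carbon, ortho to a large group, goes with a 1.1-fold higher number from compound 2 to compound 3 (0.02 log units; within the scatter) in this assay and chloro in place of hydrogen goes with a 1.2-fold lower number from compound 1 to compound 3 (0.07 log units; within the scatter) at the same spot. Hydrogen, methoxy and chloro have now all been read at this one place, and the three compounds cannot be told apart, so the earlier flat pair is joined by a group of a different kind, one that counts a chlorine atom and no hydrogen-bond acceptor where methoxy counts one. No measurement here offers an explanation for why these readings sit together.

The compounds shown leave open whether any group at this place can move the number beyond the scatter, for instance an amine, a carboxylic acid or a longer chain such as butoxy. They also leave open how much the number depends on the rest of the shared core, since compound 1, compound 2 and compound 3 differ at this one place only.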